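The source may hold more compounds than are shown below. What is called first, only, known or untested is meant among the compounds shown, and "the series" means these compounds.

Compound 1 `Cc1ccc2c(c1)c(O)c(C1=CS(=O)(=O)c3cc(NS(C)(=O)=O)ccc3N1)c(=O)n2Cc1ccc(F)cc1` is the starting point. In an ADME assay on 2209-23 cells (Homo sapiens) for cytotoxicity, read by WST assay (on this read-out higher numbers stand for lower toxicity in this test and lower numbers for higher toxicity in this test), compound 1 gives only a limit, > 50000 nM. Compound 2 `COc1ccc2c(c1)c(O)c(C1=CS(=O)(=O)c3cc(NS(C)(=O)=O)ccc3N1)c(=O)n2Cc1ccc(F)cc1` carries methoxy in place of methyl on an aromatic carbon. In this assay compound 2 likewise gives only a limit, > 50000 nM. The step that the two limits leave unreadable from compound 1 to compound 2 therefore cannot be read from these two results. Compound 3 `Cc1cc(Cn2c(=O)c(C3=CS(=O)(=O)c4cc(NS(C)(=O)=O)ccc4N3)c(O)c3cc(F)ccc32)ccc1F` is built on another core, and the difference between the two cores is not broken down here. In this assay compound 3 again gives only a limit, > 50000 nM. Compound 4 `COc1cc(Cn2c(=O)c(C3=CS(=O)(=O)c4cc(NS(C)(=O)=O)ccc4N3)c(O)c3cc(F)ccc32)ccc1F` has not yet been measured; it differs from compound 3 by methoxy in place of methyl on an aromatic carbon, the same kind of change as that from compound 1 to compound 2, though the place is not the same: here it is ortho to a fluoro group and meta to a large group, whereas in compound 2 it is meta to a fused ring and para to a fused ring. Compound 4 is expected to stay at the same limit, an expected step of a number no higher from compound 3 to compound 4 (the limit leaves the size open) beside the unreadable earlier one, because the limit of > 50000 nM in this assay, at which 3 of the 3 values shown sit, holds for every value shown. The estimate for compound 4 is 50000 nM, between 25000 nM and 100000 nM.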

Compound 4, half-maximal cytotoxic concentration: > 50000 nM
Compound 4 ended at the assay's limit (the forecaster's own chance of this, stated with the estimate: 85%); the middle value lies on the limit itself.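

Compound 3 and compound 4 both give only a limit in this assay, so no step can be read between them, just as none can be read between compound 1 and compound 2. The compounds shown leave open whether methoxy in place of methyl changes the read-out at all, since all of them share one result: the limit of > 50000 nM in this assay, at which 4 of the 4 values shown sit.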